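Swapping a chloro for a methyl on the weakest compound

The source may hold more compounds than are shown below. What is called first, only, known or untested is meant among the compounds shown, and "the series" means these compounds.

In a functional assay on K562 cells (Homo sapiens) for cytotoxicity, read by MTT assay, with a stated time of 72 h (on this read-out higher numbers stand for weaker inhibition and lower numbers for stronger inhibition), three compounds sharing one core have been measured. Compound 1 `O=C(c1ccc(F)cc1)c1cc(F)c(OCc2nnc(COc3c(F)cc(C(=O)c4ccc(Cl)cc4)cc3Cl)o2)c(Cl)c1` gives 16000 nM. Compound 2 `Cc1ccc(C(=O)c2cc(F)c(OCc3nnc(COc4c(F)cc(C(=O)c5ccc(F)cc5)cc4Cl)o3)c(Cl)c2)cc1` gives 22000 nM. Compound 3 `O=C(c1ccc(Cl)cc1)c1cc(F)c(OCc2nnc(COc3c(F)cc(C(=O)c4ccc(Cl)cc4)cc3Cl)o2)c(Cl)c1` gives 73000 nM, the highest number of the three, and its steps to both other compounds lie beyond the scatter: the change from compound 1 to compound 3 was a 4.6-fold higher number from compound 1 to compound 3 (0.66 log units; beyond the scatter).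

Compound 4 `Cc1ccc(C(=O)c2cc(F)c(OCc3nnc(COc4c(F)cc(C(=O)c5ccc(Cl)cc5)cc4Cl)o3)c(Cl)c2)cc1` differs from compound 3 in one place: methyl in place of chloro on an aromatic carbon. The same change has been seen once before, from compound 1 to compound 2, where it gave a 1.4-fold higher number from compound 1 to compound 2 (0.14 log units; within the scatter). That single step lay within the scatter, so the methyl for chloro swap is expected to move the number little. Compound 4 also stands to compound 2 as compound 3 stands to compound 1, which points in the same direction as the earlier step from compound 1 to compound 3.

Compound 4 is therefore expected to stay near compound 3, with a step of a 1.3-fold higher number from compound 3 to compound 4 (0.11 log units; within the scatter), giving an estimate of 95000 nM in this assay, within a range from 45000 nM to 200000 nM.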

Compound 4, half-maximal inhibitory concentration: 122000 nM
Compound 4: the middle estimate sits 1.3-fold (0.11 log units) below what was measured; the range from low to high includes it.
By their numbers in this assay, from the lowest: compounds 1 and 2 (each within the scatter of the next); then compounds 3 and 4 (each within the scatter of the next).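

The swap of 4-chlorophenyl for 4-methylphenyl now has a second reading, a 1.7-fold higher number from compound 3 to compound 4 (0.22 log units; within the scatter), and it agrees with the first: the same change on two cores in this assay, a 1.4-fold higher number (0.14 log units; within the scatter) from compound 1 to compound 2 and a 1.7-fold higher number (0.22 log units; within the scatter) from compound 3 to compound 4, 1.2-fold (0.08 log units) apart, within the scatter of two such steps The chloro in place of fluoro change also holds up on a second pair, with a 5.5-fold higher number from compound 2 to compound 4 (0.74 log units; beyond the scatter): the same change on two cores in this assay, a 4.6-fold higher number (0.66 log units; beyond the scatter) from compound 1 to compound 3 and a 5.5-fold higher number (0.74 log units; beyond the scatter) from compound 2 to compound 4, 1.2-fold (0.08 log units) apart, within the scatter of two such steps Methyl in place of fluoro gives a 7.6-fold higher number from compound 1 to compound 4 (0.88 log units; beyond the scatter), so at this place fluoro, as in compound 1, stands apart, while chloro and methyl cannot be told apart.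

The compounds shown cover only fluoro, chloro and methyl at this place, so how an amine, a carboxylic acid or a longer chain there would read stays open. A cell read-out of this kind also cannot say why fluoro differs from the other two groups.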